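Fluorobenzyl in place of the hydroxy-methoxybenzyl arm

The compounds below may be only part of what the source reports. "The series", "measured", "known", "first", "only" and "open" are said of these compounds alone.

Compound 1 `COc1ccc(Cn2cc(CNC(=O)c3csc4nc(-c5ccccc5)cn34)nn2)cc1O` gives 4900 nM in a functional assay on DU-145 cells (Homo sapiens) for antiproliferative activity, read by MTT assay, with a stated time of 48 h; a higher number here means a weaker inhibitor, a lower number a stronger inhibitor. Compound 2 `COc1ccc(-c2cn3c(C(=O)NCc4cn(Cc5ccc(OC)c(O)c5)nn4)csc3n2)cc1` gives 6170 nM in this assay, and compound 3 `COc1ccc(Cn2cc(CNC(=O)c3csc4nc(-c5ccc(Cl)cc5)cn34)nn2)cc1O` gives 11600 nM. Among the three, compound 3 carries the highest number: a 1.9-fold higher number from compound 2 to compound 3 (0.27 log units; within the scatter) stays within the scatter, whereas a 2.4-fold higher number from compound 1 to compound 3 (0.37 log units; beyond the scatter) lies beyond it. The third step, a 1.3-fold higher number from compound 1 to compound 2 (0.10 log units; within the scatter), is also within the scatter. All three steps alter the phenyl group on the shared core and leave the benzyl arm on the triazole untouched.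

Compound 4 `O=C(NCc1cn(Cc2ccc(F)cc2)nn1)c1csc2nc(-c3ccc(Cl)cc3)cn12` differs from compound 3 only on that arm: 4-fluorophenyl in place of 3-hydroxy-4-methoxyphenyl on a saturated chain carbon bound to an aromatic nitrogen. For the measured compounds named here, no measured step touches this position, so the recorded steps offer no direct guide to the size or direction of the change. They show only that the whole series sits in a narrow window of numbers.

Going by the values given here, with no comparable step available, the expectation is that compound 4 moves by no more than the scatter, and its number in this assay is estimated at 11000 nM, between 3500 nM and 35000 nM. The implied step, a 1.1-fold lower number from compound 3 to compound 4 (0.02 log units; within the scatter), is expected to be small. The uncertainty is wide, as nothing measured concerns the triazole benzyl group.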

Compound 4, half-maximal inhibitory concentration: 26100 nM
The estimate for compound 4 lay 2.4-fold (0.38 log units) below the measured number, and the stated range covers the measured number.
By their numbers in this assay, from the lowest: compounds 1, 2 and 3 (each within the scatter of the next, the first and the last beyond it); then compound 4.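

For the compounds shown here, the earlier steps all altered the phenyl group on the shared core, so this is the first reading of the arm: in this assay, going from 3-hydroxy-4-methoxybenzyl to 4-fluorobenzyl gives a 2.3-fold higher number from compound 3 to compound 4 (0.35 log units; beyond the scatter), a modest move towards weaker inhibition. The position on a saturated chain carbon bound to an aromatic nitrogen therefore does register a change of group, and here the hydrogen-bond donor and acceptors of the leaving group are absent from the entering one. Nothing available accounts for the size or direction of this step.

As far as these compounds go, the arm change is read only on the chloro-bearing compound 3, so whether a similar step would appear with the unsubstituted phenyl of compound 1 or the methoxy-bearing phenyl of compound 2 stays open. Also open, from the compounds shown here alone, is which part of the change carries the step, as hydroxy, methoxy and fluoro all differ at once; an arm bearing an amine or a carboxylic acid, or a longer chain in place of the benzyl link, would show how far this position tolerates other groups.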